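This account rests on a few compounds, and the source may have more. Where it says the series, first, only, none or still open, it means among the compounds named here.

Working notes on the series, read in a functional assay on NB1 cells (Homo sapiens) for cytotoxicity, read by MTT assay, with a stated time of 3 days; a higher number here means a weaker inhibitor, a lower number a stronger inhibitor. Compound 1 `N#Cc1c(Nc2ccccc2)nc(SCc2nc3ccccc3[nH]2)nc1-c1ccccc1` gives 2.5 nM, compound 2 `CNc1nc(SCc2nc3ccccc3[nH]2)nc(-c2ccccc2)c1C#N` gives 4.46 nM, and compound 3 `N#Cc1c(NNC(N)=S)nc(SCc2nc3ccccc3[nH]2)nc1-c1ccccc1` gives 5.81 nM. Compound 3 is not separated from compound 2, with a 1.3-fold higher number from compound 2 to compound 3 (0.11 log units; within the scatter). Its gap to compound 1 is modest, with a 2.3-fold higher number from compound 1 to compound 3 (0.37 log units; beyond the scatter).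

The next structure is compound 4 `N#Cc1c(NC(N)=S)nc(SCc2nc3ccccc3[nH]2)nc1-c1ccccc1`, and the change is a group of 3 heavy atoms (1 carbon, 1 nitrogen, 1 sulfur; no ring) in place of a group of 4 heavy atoms (1 carbon, 2 nitrogen, 1 sulfur; no ring), on a nitrogen on an aromatic ring. The change falls on a nitrogen on an aromatic ring, the same place that differs among the three measured compounds, so all three measured steps bear on it. Besides the two steps above, there is a 1.8-fold higher number from compound 1 to compound 2 (0.25 log units; within the scatter). For the measured compounds named here, exchanging the group at this place has therefore moved the number only slightly in these three compounds, and only the step to compound 3 from compound 1 clears the scatter. Going by the values given here, no measured pair isolates the exact difference between compound 3 and compound 4, so the expectation rests on this narrow spread alone. No step beyond the scatter is expected in this assay, and no direction is favoured. The estimate corresponds to an expected 1.2-fold lower number from compound 3 to compound 4 (0.07 log units; within the scatter). For compound 4 the estimated value is 5 nM, with an expected range of 2 nM to 12 nM.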

Compound 4, half-maximal inhibitory concentration: 11.9 nM
For compound 4 the middle estimate is 2.4-fold (0.38 log units) below the measured one; low and high end bracket the measured number.
By their numbers in this assay, from the lowest: compounds 1, 2 and 3 (each within the scatter of the next, the first and the last beyond it); then compound 4.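

In this assay, for the compounds shown here, the group of 3 heavy atoms on a nitrogen on an aromatic ring gives the first compound that separates from all the others: a 2.0-fold higher number from compound 3 to compound 4 (0.31 log units; beyond the scatter), a 2.7-fold higher number from compound 2 to compound 4 (0.43 log units; beyond the scatter) and a 4.8-fold higher number from compound 1 to compound 4 (0.68 log units; beyond the scatter), each beyond the scatter. Going by these compounds alone, earlier, only the step between compound 1 and compound 3 cleared the scatter, so this place is less tolerant of exchange than those three compounds suggested, and a change of a single nitrogen in a group without a ring is enough to register. Group size does not order the series, as compound 2 with one carbon atom and compound 1 with a six-membered aromatic ring both give lower numbers than compound 4, and nothing available here explains why the number moves at this place.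

Still open, going by these compounds, is whether a plain amine, a longer alkyl chain or a urea with a carbonyl in place of the sulfur would stay with compounds 1, 2 and 3 or move towards compound 4. Also open, on these data alone, is whether the same ordering holds in any other cell line, since all four values come from one assay.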